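The source may report more compounds than this note shows. Statements on the series, on what has been measured and on what is new or still open speak of the compounds shown alone.

Compound 1 `Cc1ncnc2c1c(-c1ccsc1)cn2[C@@H]1O[C@H](CO)[C@@H](O)[C@H]1O`: 5550 nM
Compound 2 `Nc1nc2c(c(-c3ccco3)cn2[C@@H]2O[C@H](CO)[C@@H](O)[C@H]2O)c(=O)[nH]1`: > 20000 nM

Both compounds were tested in a functional assay on K562 cells (Homo sapiens), read by MTT assay, with a stated time of 72 h; on this read-out higher numbers stand for weaker inhibition and lower numbers for stronger inhibition. For compound 2, the result > 20000 nM is a limit of the assay and not a number. Compound 3 `Nc1nc2c(c(-c3ccoc3)cn2[C@@H]2O[C@H](CO)[C@@H](O)[C@H]2O)c(=O)[nH]1` differs from compound 2 only in the furan ring: furan-3-yl in place of furan-2-yl on an aromatic carbon, with furan-3-yl in place of furan-2-yl on an aromatic carbon. Going by the values given here, no measured pair shows what this swap does, so no change beyond the usual scatter is expected, and compound 3 may also be reported only as a limit. The estimated step is a number no higher from compound 2 to compound 3 (the limit leaves the size open). The expected value for compound 3 is 20000 nM, with an estimated range of 8000 nM to 40000 nM.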

Compound 3, half-maximal inhibitory concentration: 12500 nM
Estimate against measurement, compound 3: 1.6-fold (0.20 log units) above, within the range that was stated.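

With furan-3-yl in place of furan-2-yl on an aromatic carbon, this assay yields a true number rather than only a limit. As far as these compounds go, the swap gives an at least 1.6-fold lower number from compound 2 to compound 3 (0.20 log units; that floor lies within the scatter), so the real size of the step stays open and could be larger. Compound 2 is held by a limit, not a number: the limit of > 20000 nM in this assay, at which 1 of the 3 values shown sits.

From the compounds shown here alone, what an amine or a carboxylic acid would do on this same carbon remains open. Compound 1 differs from compound 3 in more than one place, so it cannot settle this.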